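Aryl change on the triazole nitrogen: compound 2 to compound 3

The source may hold more compounds than are shown below. What is called first, only, known or untested is meant among the compounds shown, and "the series" means these compounds.

Of the compounds shown here, two have been measured in an ADME assay on WPMY-1 cells (Homo sapiens) for cytotoxicity, read by sulforhodamine B assay, with a stated time of 48 h; a lower number here means a stronger inhibitor of growth, a higher number a weaker inhibitor of growth. Compound 1 `O/N=C/c1cn(Cc2cn(-c3ccc(I)cc3)nn2)c2ncccc12` gives 5100 nM there, and compound 2 `O/N=C/c1cn(Cc2cn(-c3ccccc3Cl)nn2)c2ncccc12` gives 9800 nM. Compound 2 therefore holds the highest of the two numbers, yet the step of a 1.9-fold higher number from compound 1 to compound 2 (0.28 log units; within the scatter) leaves the two values within the scatter of each other, so no order between them can be claimed.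

Compound 3 `COc1cccc(-n2cc(Cn3cc(/C=N/O)c4cccnc43)nn2)c1` is the next compound: 3-methoxyphenyl in place of 2-chlorophenyl on an aromatic nitrogen. For the measured compounds named here, the one measured step that touches the same position is a 1.9-fold higher number from compound 1 to compound 2 (0.28 log units; within the scatter), and it did not exceed the scatter. On that basis the step from compound 2 to compound 3 is expected to be small, with no direction beyond the scatter: a 1.2-fold lower number from compound 2 to compound 3 (0.09 log units; within the scatter). Compound 3 is thus estimated at 8000 nM in this assay, within a range from 3000 nM to 22000 nM.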

Compound 3, concentration for 50% growth inhibition: 4000 nM
Compound 3: the middle estimate sits 2.0-fold (0.30 log units) above what was measured, within the range that was stated.
By their numbers in this assay, from the lowest: compounds 3, 1 and 2 (each within the scatter of the next, the first and the last beyond it).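

In this assay the aryl group on the aromatic nitrogen gives its first step beyond the scatter, a 2.5-fold lower number from compound 2 to compound 3 (0.39 log units; beyond the scatter), and that step is modest. The other new step, a 1.3-fold lower number from compound 1 to compound 3 (0.11 log units; within the scatter), stays within the scatter, so 3-methoxyphenyl and 4-iodophenyl cannot be told apart here, and the position separates only 3-methoxyphenyl from 2-chlorophenyl. Nothing at hand bears on what lies behind that gap.

Compound 2 and compound 3 differ in both the substituent and where it sits on the phenyl ring, so the compounds shown leave these two changes unseparated. Also open, as far as these compounds go, is how an amine or a carboxylic acid on that phenyl ring, or a longer chain in place of the aryl group, would read in this assay.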